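This account rests on a few compounds, and the source may have more. Where it says the series, first, only, none or still open, it means among the compounds named here.

Three compounds built on one shared core were measured in an assay on liver for binding affinity to Alpha-1D adrenergic receptor (Homo sapiens), using microsomes; on this read-out higher numbers stand for weaker inhibition and lower numbers for stronger inhibition. Compound 1 `COC(=O)C1=C(C)NC(=O)N(C(=O)NCCCN2CCN(c3ccccc3OC)CC2)C1c1ccc(F)c(F)c1` gives 31 nM. Compound 2 `COC(=O)C1=C(C)NC(=O)N(C(=O)NCCCN2CCN(c3ccccc3O)CC2)C1c1ccc(F)c(F)c1` gives 31 nM, level with compound 1, and the two stand together as the highest of the three numbers. Compound 3 `CCOc1ccccc1N1CCN(CCCNC(=O)N2C(=O)NC(C)=C(C(=O)OC)C2c2ccc(F)c(F)c2)CC1` gives 14 nM. The step of no change at the digits printed from compound 1 to compound 2 (within the scatter) stays within the scatter, while a 2.2-fold lower number from compound 1 to compound 3 (0.35 log units; beyond the scatter) and a 2.2-fold lower number from compound 2 to compound 3 (0.35 log units; beyond the scatter) are modest. Compound 4 `COC(=O)C1=C(C)NC(=O)N(C(=O)NCCCN2CCN(c3cccc([N+](=O)[O-])c3)CC2)C1c1ccc(F)c(F)c1` differs from compound 2 by 3-nitrophenyl in place of 2-hydroxyphenyl on an amine nitrogen in a ring. Among the compounds with values here, no measured step covers such a swap of the whole ring substituent; the known steps only vary the group on the ring oxygen and shift this assay little. The expectation for compound 4 is a step of a 1.9-fold higher number from compound 2 to compound 4 (0.29 log units; within the scatter), with wide uncertainty. Compound 4 is thus estimated at 60 nM, within a range from 15 nM to 250 nM.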

Compound 4, inhibition constant: 340 nM
Beside the measured number, compound 4's estimate is 5.7-fold (0.75 log units) below it; measured number outside the range, above it.
By their numbers in this assay, from the lowest: compound 3; then compounds 1 and 2 (each within the scatter of the next); then compound 4.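

In this assay, swapping the whole aryl group on the ring amine nitrogen for 3-nitrophenyl gives an 11-fold higher number from compound 2 to compound 4 (1.04 log units; beyond the scatter) and an 11-fold higher number from compound 1 to compound 4 (1.04 log units; beyond the scatter) and a 24-fold higher number from compound 3 to compound 4 (1.39 log units; beyond the scatter). All three steps are large, whereas changing only the group on the ring oxygen gave modest steps at most, so this position is far less forgiving of the new aryl group. No measured evidence here accounts for the loss.

Compound 4 changes both the substituent and its place on the aryl ring, and the compounds shown cannot separate those two changes. From the compounds shown here alone, how a plain phenyl group, or an amine in place of the nitro group, would read out remains open.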